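Formyl(hydroxy)amino to hydroxycarbamoyl: an expected step

The source may report more compounds than this note shows. Statements on the series, on what has been measured and on what is new or still open speak of the compounds shown alone.

Measured compounds:
Compound 1, `O=CN(O)C(CCc1ncccn1)CS(=O)(=O)N1CCN(c2ccc(Cl)cn2)CC1`, in an ADME assay for inhibition of Bile salt export pump (Homo sapiens), read by scintillation counting, with a stated time of 5 min (on this read-out higher numbers stand for weaker inhibition and lower numbers for stronger inhibition), gives < 10000 nM, which is a limit of the assay and not a number.
Compound 2, `O=CN(O)C(CCc1ccccc1)CS(=O)(=O)N1CCN(c2ccc(F)cc2)CC1`, gives < 10000 nM in this assay, again a limit rather than a number.
Compound 3, `CCOCCNS(=O)(=O)c1ccc(Nc2nccc(-c3cnc(C)n3C(C)C)n2)cc1`, gives < 10000 nM in this assay, also a limit.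

Compound 2 therefore stands where everything measured so far stands, at the limit, as the limit of < 10000 nM in this assay, at which 3 of the 3 values shown sit, records; no measured number separates it from compound 1 or compound 3, and nothing in these values ranks the three against one another. Going by the values given here, no step between measured compounds is available, so the move to compound 4, `O=C(NO)C(CCc1ccccc1)CS(=O)(=O)N1CCN(c2ccc(F)cc2)CC1`, rests on structure alone: hydroxycarbamoyl in place of formyl(hydroxy)amino on a saturated chain carbon bound to two saturated chain carbons. The two compounds hold the same atoms, joined differently, on the shared core of compound 2. Among the compounds with values here, with no measured step to lean on, the step that the limit leaves unreadable from compound 2 to compound 4 is expected to be none beyond the usual scatter of this assay, in either direction. Compound 4 is estimated at 3000 nM, within a range from 500 nM to 10000 nM, and is expected most likely to be reported as a limit as well.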

Compound 4, half-maximal inhibitory concentration: < 10000 nM
Compound 4 gave a limit, no number; the forecaster's own chance of this, stated with the estimate: 80%; the middle value is on the limit's open side.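

No step can be read from compound 2 to compound 4 in this assay, since each gives a limit and not a number: the limit of < 10000 nM in this assay, at which 4 of the 4 values shown sit.

The compounds shown leave open whether hydroxycarbamoyl in place of formyl(hydroxy)amino changes anything in this assay, and how the four compounds rank against one another.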